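Adding a Cyclopropylmethyl Group to an Indole Nitrogen

The source may report more compounds than this note shows. Statements on the series, on what has been measured and on what is new or still open speak of the compounds shown alone.

Measured so far: compound 1 `FC(F)(F)Cc1cnc2c(Cl)c(-c3cc(Cl)c4c(ccn4CC4CC4)c3)ccn12`, 250 nM; compound 2 `N#Cc1c(-c2cc(Cl)c3[nH]ccc3c2)ccn2c(CC(F)(F)F)cnc12`, 320 nM.

Compound 2 has the highest of the two numbers in a functional assay on CHO cells for agonist activity at metabotropic glutamate receptor 2 (Homo sapiens), read by GTPgammaS binding (a higher number here means that more compound is needed for the effect, a lower number that less compound is needed), though compound 1 lies within the scatter of it. Compound 3 `N#Cc1c(-c2cc(Cl)c3c(ccn3CC3CC3)c2)ccn2c(CC(F)(F)F)cnc12` has not been measured. It differs from compound 2 by cyclopropylmethyl in place of hydrogen on an aromatic nitrogen. Compound 1 already carries this group, though on a different core, and its value is close to that of compound 2, so no step beyond the scatter is clearly expected. The estimated step from compound 2 to compound 3 is a 1.6-fold lower number from compound 2 to compound 3 (0.20 log units; within the scatter). Compound 3 is expected to give about 200 nM, within 60 nM to 650 nM.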

Compound 3, half-maximal effective concentration: 110 nM
Beside the measured number, compound 3's estimate is 1.8-fold (0.26 log units) above it, within the range that was stated.
By their numbers in this assay, from the lowest: compound 3; then compounds 1 and 2 (each within the scatter of the next).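

In this assay there is a 2.9-fold lower number from compound 2 to compound 3 (0.46 log units; beyond the scatter) with cyclopropylmethyl in place of hydrogen on the aromatic nitrogen, so on this core the group brings a change beyond the scatter, something compound 1 and compound 2 could not show. With that group in place, cyano in place of chloro on an aromatic carbon also counts, with a 2.3-fold lower number from compound 1 to compound 3 (0.36 log units; beyond the scatter) as its step. Nothing measured here explains either step.

Going by these compounds, whether methyl or a longer chain such as butyl on the same nitrogen would give a lower or higher number remains open. So does the size of the cyclopropylmethyl step on the chloro core of compound 1.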